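The compounds below may be only part of what the source reports. "The series", "measured", "known", "first", "only" and "open" are said of these compounds alone.

Measured so far:
compound 1 `CCCCCCCCc1ccc(OCC(=O)Cn2nnnc2-c2ccc(S(=O)(=O)N(C)C)cc2)cc1` — 1400 nM
compound 2 `CCCCCCCCc1ccc(OCC(=O)Cn2nnnc2-c2cccnc2)cc1` — 190 nM
compound 3 `CCCCCCCCc1ccc(OCC(=O)Cn2nnnc2-c2cccs2)cc1` — 55 nM

All three were tested in an assay on microsomes from brain for inhibition of Fatty-acid amide hydrolase 1 (Rattus norvegicus), read by fluorescence and HPLC, with a stated time of 60 min; on this read-out higher numbers stand for weaker inhibition and lower numbers for stronger inhibition. Compound 3 gives the lowest number of the three, and both gaps to it lie beyond the scatter: a 3.5-fold lower number from compound 2 to compound 3 (0.54 log units; beyond the scatter) and a 25-fold lower number from compound 1 to compound 3 (1.41 log units; beyond the scatter). The remaining pair shows a 7.4-fold lower number from compound 1 to compound 2 (0.87 log units; beyond the scatter).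

The new compound, compound 4 `CCCCCCCCc1ccc(OCC(=O)Cn2nnnc2Cc2ccccc2)cc1`, keeps the core of compound 3 and changes one group: benzyl in place of thiophen-2-yl on an aromatic carbon. For the measured compounds named here, none of the measured steps swaps an aromatic ring for a ring attached through a one-carbon link, so no step bears on this change directly. The three steps do show that the group at this position moves the number over a wide span, from modest to large, so a change beyond the scatter in either direction is possible. Going by the values given here, with no close precedent, the expectation is a modest shift toward a higher number, a 2.7-fold higher number from compound 3 to compound 4 (0.44 log units; beyond the scatter), and compound 4 is estimated at 150 nM, with a range from 40 nM to 600 nM.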

Compound 4, half-maximal inhibitory concentration: 320 nM
Beside the measured number, compound 4's estimate is 2.1-fold (0.33 log units) below it; low and high end bracket the measured number.
By their numbers in this assay, from the lowest: compound 3; then compounds 2 and 4 (each within the scatter of the next); then compound 1.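

Benzyl, whose ring is held through a one-carbon link instead of being attached directly, keeps inhibition at this position but does not match thiophen-2-yl: a 5.8-fold higher number from compound 3 to compound 4 (0.76 log units; beyond the scatter). The linked ring cannot be told apart from pyridin-3-yl, a 1.7-fold higher number from compound 2 to compound 4 (0.23 log units; within the scatter), and still improves on 4-(dimethylsulfamoyl)phenyl, a 4.4-fold lower number from compound 1 to compound 4 (0.64 log units; beyond the scatter), so compound 4 falls inside the span already set by the directly attached rings. No measurement here offers an explanation for these differences.

Benzyl changes both the link and the ring, so the share of each in the step remains open; a directly attached phenyl or a thiophen-2-ylmethyl group would separate them. Also open, going by these compounds, is how a longer link, as in 2-phenylethyl, or an amine on the link would behave at this position.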